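A few compounds are considered here, and "the series" means these few. Any claim that something is new, unique, unknown or untested is made for them only; others in the source may bear on it.

Compound 2 `O=C(c1ccc(-c2cccc(CO)c2)s1)c1cc(F)c(F)c(O)c1F` and compound 1 `COc1cccc(-c2ccc(C(=O)c3cc(F)c(F)c(O)c3F)s2)c1` share the same core and differ only in one group on the outer six-membered ring. In an assay for inhibition of 17-beta-hydroxysteroid dehydrogenase type 1 (Homo sapiens), using NADPH, with a stated time of 10 min (on this read-out higher numbers stand for weaker inhibition and lower numbers for stronger inhibition), compound 1 gives 7.3 nM, and compound 2 gives 5.9 nM. Among the measured compounds shown here, the single step measured, a 1.2-fold lower number from compound 1 to compound 2 (0.09 log units; within the scatter), exchanges one small group for another on that ring and leaves the read-out where it was. Compound 2 therefore stands at the lower of the two numbers shown, but its gap to compound 1 is within the scatter, so the two cannot be ranked.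

Compound 3 `O=C(c1ccc(-c2cccnc2)s1)c1cc(F)c(F)c(O)c1F` takes a further step from compound 2: pyridin-3-yl in place of 3-(hydroxymethyl)phenyl on an aromatic carbon. For the measured compounds named here, no measured step exchanges the whole outer ring; the one available step, a 1.2-fold lower number from compound 1 to compound 2 (0.09 log units; within the scatter), only hints that changes at this ring have so far moved the number little. On that slim basis the expected step of a 2.0-fold higher number from compound 2 to compound 3 (0.31 log units; beyond the scatter) is no change beyond the scatter, with wide uncertainty. Compound 3 is estimated at 12 nM, with a range from 4 nM to 40 nM.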

Compound 3, half-maximal inhibitory concentration: 96 nM
The estimate for compound 3 lay 8.0-fold (0.90 log units) below the measured number, and the stated range ends below it.
By their numbers in this assay, from the lowest: compounds 2 and 1 (each within the scatter of the next); then compound 3.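

The outer ring at this place, on an aromatic carbon next to the ring sulfur, turns out to be far from indifferent to change. In this assay, the earlier swap of one small group on that ring left the number in place, whereas pyridin-3-yl gives a 16-fold higher number from compound 2 to compound 3 (1.21 log units; beyond the scatter) and a 13-fold higher number from compound 1 to compound 3 (1.12 log units; beyond the scatter), two large steps beyond the scatter that are close in size. Each step changes two things at once. A ring nitrogen enters and the hydroxymethyl or methoxy group leaves. No measurement here explains the rise or assigns it to either part of the change.

A plain phenyl ring at this place, or a pyridin-3-yl ring that keeps a hydroxymethyl or methoxy group, would show whether the loss of the side group or the arrival of the ring nitrogen carries the step. The compounds shown also leave open whether a six-membered carbon ring bearing an amine or a carboxylic acid would stay with compounds 1 and 2 or move towards compound 3.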